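The source may hold more compounds than are shown below. What is called first, only, known or untested is meant among the compounds shown, and "the series" means these compounds.

Measured so far:
Compound 1 `CCOC(=O)C(=O)Nc1ccc(-c2nc(N)n(/C(S)=N/C)n2)cc1`, which in a functional assay on the whole organism for inhibition, with Rattus norvegicus as the target, at a dose of 30 mg/kg (a higher number here means more inhibition at the dose given (going by the name of the read-out), a lower number less inhibition), gives 49%.
Compound 2 `C/N=C(\S)Nc1ccc(-c2nc(N)n(/C(S)=N/C)n2)cc1`, which in this assay gives 31%.

For the measured compounds named here, compound 2 stands lowest of the two numbers in hand; its nearest neighbour is compound 1, and the only measured step is the one between them, a number 18 percentage points lower from compound 1 to compound 2 (beyond the scatter), where a group of 4 heavy atoms replaced a group of 7 heavy atoms on a nitrogen on an aromatic ring. Compound 3 `C/N=C(\S)n1nc(-c2ccc(F)cc2)nc1N` is not yet measured. It differs from compound 2 as follows: one fluorine atom in place of a group of 5 heavy atoms (2 carbon, 2 nitrogen, 1 sulfur; no ring), on an aromatic carbon. Going by the values given here, no measured step touches this place in the same way: the one step in hand exchanged one group for another on that nitrogen, whereas here the whole group of 5 heavy atoms leaves and a single fluorine enters in its place. That step shows only that altering this part of compound 2 can move the read-out by a modest amount. Compound 3 is therefore expected to land near compound 2 or somewhat lower, with wide uncertainty, an expected step of a number 6 percentage points lower from compound 2 to compound 3 (within the scatter). The estimate for compound 3 in this assay is 25%, ranging from 5% to 50%.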

Compound 3, a percentage reported as inhibition, in the whole organism at one dose (the size of the read-out at that dose, not a potency): 73%
For compound 3 the middle estimate is 48 percentage points below the measured one; measured number above the stated range.
By their numbers in this assay, from the lowest: compound 2; then compound 1; then compound 3.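

In this assay, for the compounds shown here, the aromatic carbon para to a large group proves to be a place where the read-out can shift strongly: with fluoro in place of the group of 5 heavy atoms, the change is a number 42 percentage points higher from compound 2 to compound 3 (beyond the scatter) and is larger than the only earlier step. The earlier step exchanged one group on the nitrogen for another, whereas fluoro in place of ((ethoxycarbonyl)carbonyl)amino gives a number 24 percentage points higher from compound 1 to compound 3 (beyond the scatter) and so places the single fluorine atom above both larger groups, not only the lower of the two. Nothing given here offers an explanation for this rise.

The compounds shown leave open whether the fluorine atom itself matters or whether other small groups on this carbon, such as a hydrogen, a chlorine atom or a methoxy group, would give similar numbers. They also leave open how an amine or a carboxylic acid at the same place would read, and whether the order of these compounds would hold at doses other than the single one tested.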